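Acetoxymethyl chalcone analogues against SW1573 cell growth

The compounds below may be only part of what the source reports. "The series", "measured", "known", "first", "only" and "open" are said of these compounds alone.

Compound 1 `CC(=O)OC/C(=C\c1ccccc1)C(=O)c1ccccc1`: 4800 nM
Compound 2 `CC(=O)OC/C(=C\c1ccc(F)cc1)C(=O)c1ccccc1`: 4200 nM

Compound 2 gives the lowest of the two numbers in a functional assay on SW1573 cells (Homo sapiens) for inhibition, read by sulforhodamine B assay, with a stated time of 48 h (a higher number here means a weaker inhibitor of growth, a lower number a stronger inhibitor of growth), with compound 1 nearest; the step of a 1.1-fold lower number from compound 1 to compound 2 (0.06 log units; within the scatter) is within the scatter, so the two compounds cannot be ordered. Compound 3 `CC(=O)OC/C(=C\c1ccc([N+](=O)[O-])cc1)C(=O)c1ccccc1` differs from compound 2 by nitro in place of fluoro on an aromatic carbon. Going by the values given here, only one measured step bears on this position on the ring: the change from hydrogen to fluoro, a 1.1-fold lower number from compound 1 to compound 2 (0.06 log units; within the scatter), which was within the scatter. Among the compounds with values here, no measured step shows a nitro group anywhere, so there is no basis for expecting a shift beyond the scatter in either direction in this assay, and the range must stay wide. Compound 3 is therefore expected to give about 3800 nM, between 1400 nM and 10000 nM. This estimate corresponds to an expected step of a 1.1-fold lower number from compound 2 to compound 3 (0.04 log units; within the scatter).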

Compound 3, concentration for 50% growth inhibition: 3800 nM
Compound 3: middle estimate and measured number agree at the digits printed; the range from low to high includes it.
By their numbers in this assay, from the lowest: compounds 3, 2 and 1 (each within the scatter of the next).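

In this assay, nitro on this aromatic carbon, para to a large group, gave a 1.1-fold lower number from compound 2 to compound 3 (0.04 log units; within the scatter) when it replaced fluoro and a 1.3-fold lower number from compound 1 to compound 3 (0.10 log units; within the scatter) when it replaced hydrogen. The position has now taken a second substituent, with three heavy atoms and two hydrogen-bond acceptors where fluoro has one heavy atom and none, and hydrogen, fluoro and nitro still cannot be ordered in this read-out. Nothing measured alongside these numbers offers an explanation for them.

On these data alone, whether an amine, a carboxylic acid or a longer chain at this same position would move the number beyond the scatter remains open. So does whether any change elsewhere on the shared core, such as a free hydroxyl in place of the acetoxy group, would do so.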